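Selenium-Benzyl for Methylsulfanyl on a Furan-Amide Core

The source may report more compounds than this note shows. Statements on the series, on what has been measured and on what is new or still open speak of the compounds shown alone.

Compound 1 `CS/C(=N\C(=O)c1ccco1)NC(=O)c1ccco1` and compound 3 `CS/C(=N\C(=O)c1cccs1)NC(=O)c1cccs1` share a central carbon with a double bond to nitrogen; the difference between the two cores is not broken down here. In an ADME assay on MCF-10A cells (Homo sapiens) for cytotoxicity, read by MTT assay, with a stated time of 72 h (on this read-out lower numbers stand for stronger inhibition of growth and higher numbers for weaker inhibition of growth), compound 1 gives 46500 nM, and compound 3 gives 55100 nM. Compound 2 `O=C(/N=C(/NC(=O)c1cccs1)[Se]Cc1ccccc1)c1cccs1` carries a group of 8 heavy atoms (7 carbon, 1 selenium; one six-membered aromatic ring of carbon only) in place of a group of 2 heavy atoms (1 carbon, 1 sulfur; no ring), on a carbon with a double bond to nitrogen. In this assay compound 2 reaches only the limit > 100000 nM, which is a limit rather than a number. That change gives an at least 1.8-fold higher number from compound 3 to compound 2 (0.25 log units; that floor lies within the scatter), resting on (the limit of > 100000 nM in this assay, at which 1 of the 3 values shown sits). Compound 4 `O=C(/N=C(/NC(=O)c1ccco1)[Se]Cc1ccccc1)c1ccco1` makes the same change on compound 1: a group of 8 heavy atoms (7 carbon, 1 selenium; one six-membered aromatic ring of carbon only) in place of a group of 2 heavy atoms (1 carbon, 1 sulfur; no ring), on a carbon with a double bond to nitrogen. The step from compound 1 to compound 4 is expected to be a 2.6-fold higher number from compound 1 to compound 4 (0.41 log units; beyond the scatter), because compound 3 showed an at least 1.8-fold higher number from compound 3 to compound 2 (0.25 log units; that floor lies within the scatter). Compound 4 is therefore estimated at 120000 nM, expected between 60000 nM and 300000 nM.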

Compound 4, concentration for total growth inhibition: 58000 nM
Compound 4: the middle estimate sits 2.1-fold (0.32 log units) above what was measured; measured number outside the range, below it.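

In this assay, placing the selenium-containing group with its six-membered aromatic ring in place of methylsulfanyl on the core of compound 1 gives a 1.2-fold higher number from compound 1 to compound 4 (0.10 log units; within the scatter). Set beside the same change on the other core, the result does not settle whether the change carries over with the same size: the same change on two cores in this assay, an at least 1.8-fold higher number (0.25 log units; that floor lies within the scatter) from compound 3 to compound 2 and a 1.2-fold higher number (0.10 log units; within the scatter) from compound 1 to compound 4; the limit leaves it open whether they differ Compound 2 stands at a limit and not at a number, so its step has no known size, only a floor: the limit of > 100000 nM in this assay, at which 1 of the 4 values shown sits.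

The selenium and the benzyl part enter together, so the compounds shown do not separate what each contributes. A benzylsulfanyl group or a methylselanyl group on the carbon with a double bond to nitrogen would be needed to pull the two apart.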